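Allyl to 2-Hydroxyethyl in a Series Held at Limits

The source may report more compounds than this note shows. Statements on the series, on what has been measured and on what is new or still open speak of the compounds shown alone.

Three compounds sharing one core have so far gone through an ADME assay on L02 cells (Homo sapiens) for cytotoxicity, read by MTT assay (a higher number here means a weaker inhibitor, a lower number a stronger inhibitor), and none has returned a number. Compound 1 `COc1ccc(/C=C/C(=O)c2ccc(OC)c3c2OC(C)(C)C=C3)cc1O` has a hydrogen on an oxygen on an aromatic ring, and compound 1 gives > 10000 nM as a limit of the assay. Compound 2 `COc1ccc(/C=C/C(=O)c2ccc(OC)c3c2OC(C)(C)C=C3)cc1OCC=C(C)C` has 3-methylbut-2-en-1-yl on that oxygen, and compound 2 gives > 10000 nM as a limit as well. Compound 3 `C=CCOc1cc(/C=C/C(=O)c2ccc(OC)c3c2OC(C)(C)C=C3)ccc1OC` has allyl there, and compound 3 stands at > 20000 nM as a limit too.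

Compound 4 `COc1ccc(/C=C/C(=O)c2ccc(OC)c3c2OC(C)(C)C=C3)cc1OCCO` is not yet measured. It swaps allyl for 2-hydroxyethyl, which is hydroxymethyl in place of vinyl on a saturated chain carbon bound to an oxygen on an aromatic ring.

Three measured changes on the same oxygen bear on this: a step that the two limits leave unreadable from compound 1 to compound 2 and a step that the two limits leave unreadable from compound 1 to compound 3 and a step that the two limits leave unreadable from compound 2 to compound 3 are the steps, and none has a size that can be read. The closest guide is therefore weak, and no step beyond the scatter is expected in this assay for this change. The expected step is a number no higher from compound 3 to compound 4 (the limit leaves the size open) and no larger. For compound 4 the estimate is 20000 nM with 10000 nM to 40000 nM as the expected range.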

Compound 4, half-maximal inhibitory concentration: > 10000 nM
Compound 4 was reported as a limit; the forecaster's own chance of this, stated with the estimate: 85%; the middle value is on the limit's open side.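

Compound 4 also gives only a limit in this assay, so its steps from compound 1, compound 2 and compound 3 cannot be read, and none has a size. The compounds shown leave open what number any of these four would give in this assay, and whether the group on that oxygen changes that number at all.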